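The compounds below may be only part of what the source reports. "The series", "measured", "known", "first", "only" and "open" are said of these compounds alone.

Measured in an ADME assay on MT4 cells (Homo sapiens) for cytotoxicity, read by MTT assay, with a stated time of 4 days; on this read-out lower numbers stand for higher toxicity in this test and higher numbers for lower toxicity in this test:
compound 1 `Cc1ccccc1-c1cc(C)c(Nc2ccnc(Nc3ccc(C#N)cc3)n2)c(C)c1` gives 3820 nM
compound 2 `COc1ccccc1-c1cc(C)c(Nc2ccnc(Nc3ccc(C#N)cc3)n2)c(C)c1` gives 940 nM
compound 3 `Cc1cc(-c2c(C)cccc2C)cc(C)c1Nc1ccnc(Nc2ccc(C#N)cc2)n1` gives 2590 nM

Compound 3 stands second highest of the three numbers. Its nearest neighbour is compound 1: a 1.5-fold lower number from compound 1 to compound 3 (0.17 log units; within the scatter). The furthest is compound 2: a 2.8-fold higher number from compound 2 to compound 3 (0.44 log units; beyond the scatter). The remaining step, a 4.1-fold lower number from compound 1 to compound 2 (0.61 log units; beyond the scatter), shows that a methoxy in place of methyl on an aromatic carbon is enough to move the number beyond the scatter.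

Compound 4 `Cc1cc(-c2cccc(Cl)c2)cc(C)c1Nc1ccnc(Nc2ccc(C#N)cc2)n1` differs from compound 3 as follows: 3-chlorophenyl in place of 2,6-dimethylphenyl on an aromatic carbon. Within the data shown here, no measured pair brings in a chlorine, so the bearing steps are indirect. Among the measured compounds shown here, the step of a 2.8-fold higher number from compound 2 to compound 3 (0.44 log units; beyond the scatter) is the only one that exchanges one whole aryl group for another, and it was modest; a 1.5-fold lower number from compound 1 to compound 3 (0.17 log units; within the scatter) stayed within the scatter. A step of at most modest size in either direction is therefore plausible for compound 4, with no firm direction. The estimate for compound 4 is 2500 nM, with a range from 1000 nM to 6500 nM. This amounts to an expected step of a 1.0-fold lower number from compound 3 to compound 4 (0.02 log units; within the scatter).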

Compound 4, half-maximal cytotoxic concentration: 2160 nM
Compound 4: the middle estimate sits 1.2-fold (0.06 log units) above what was measured; low and high end bracket the measured number.
By their numbers in this assay, from the lowest: compound 2; then compounds 4, 3 and 1 (each within the scatter of the next).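

In this assay, among these compounds, chlorine appears on this aryl group for the first time, and the 3-chlorophenyl compound cannot be told apart from either methyl-bearing aryl compound (a 1.2-fold lower number from compound 3 to compound 4 (0.08 log units; within the scatter); a 1.8-fold lower number from compound 1 to compound 4 (0.25 log units; within the scatter)). Against the 2-methoxyphenyl group, the picture differs (a 2.3-fold higher number from compound 2 to compound 4 (0.36 log units; beyond the scatter)), so compound 2 now stands apart from three different aryl groups, with a modest step to each. No supporting measurement bears on why compound 2 alone stands apart.

Still open, on these data alone, is whether the lower number of compound 2 belongs to the methoxy group alone or also holds for an ethoxy or a hydroxyl on this aryl group. As far as these compounds go, it is also open whether an amine or a carboxylic acid there would move the number beyond the scatter, and in which direction.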